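Cyclopropyl in place of phenylsulfanyl on a benzofuran-free core

This account rests on a few compounds, and the source may have more. Where it says the series, first, only, none or still open, it means among the compounds named here.

Compound 1 `c1ccc(Sc2nn3cc(-c4cc5ccccc5o4)nc3s2)cc1` is the starting point of this comparison, yet in an ADME assay on microsomes from liver (Rattus norvegicus) for metabolic stability, with a stated time of 10 min (on this read-out higher numbers stand for a more stable compound and lower numbers for a less stable compound), compound 1 has only the entry "not determined" (no result reported), so no single number places it on the scale. For the measured compounds named here, the one measured neighbour, compound 2 `COc1cc(OCc2cccc(CCc3ccccc3)c2)c2cc(-c3cn4nc(OC)sc4n3)oc2c1`, gives in this assay compound 2 a remaining fraction of 68%. Compound 3 `c1ccc2oc(-c3cn4nc(C5CC5)sc4n3)cc2c1` differs from compound 1 by the change (cyclopropyl in place of phenylsulfanyl on an aromatic carbon), a smaller group taking the place of a larger one on the shared core. Going by the values given here, no step between two measured compounds is recorded, so the size and direction of the move into compound 3 in this assay cannot be read off; a shift either way, possibly beyond the usual scatter, is expected, with the value of compound 2 as the only anchor. For compound 3 the estimated result in this assay is 55%, expected to lie between 25% and 85%.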

Compound 3, percent of the compound remaining: 53%
Beside the measured number, compound 3's estimate is 2 percentage points above it; the range from low to high includes it.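

In this assay, for the compounds shown here, compound 3 gives 53% and compound 1 gives "not determined" (no result reported), so no step between them can be read. Going by these compounds, what cyclopropyl in place of phenylsulfanyl does on this read-out stays open. Nothing at hand bears on a cause for the result.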